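The source may report more compounds than this note shows. Statements on the series, on what has been measured and on what is new or still open speak of the compounds shown alone.

Of the compounds shown here, three sharing one core have been tested in an assay on isolated protein with malate dehydrogenase, mitochondrial (Sus scrofa) as the target; on this read-out higher numbers stand for weaker inhibition and lower numbers for stronger inhibition. Compound 1 `O=C(O)c1cnc2cc(OCc3c(Cl)c(Cl)c(Cl)c(Cl)c3Cl)ccc2c1O` carries a large substituted benzyloxy group on the carbon-only ring of the core and gives 4790 nM. Compound 3 `O=C(O)c1cnc2cc(OCCc3ccc(Br)cc3)ccc2c1O` carries a bromophenylethoxy group at the same spot and gives 2510 nM. Compound 2 `O=C(O)c1ccc2c(O)c(C(=O)O)cnc2c1` has neither of these and instead bears a second carboxy group on that ring; in this assay compound 2 gives 1070000 nM, the highest of the three numbers, and its gaps to compound 1 and to compound 3 both lie beyond the usual scatter.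

Compound 4 `O=C(O)c1cnc2cc(O)ccc2c1O` is not yet measured. It differs from compound 2 in one place: hydroxy in place of carboxy on an aromatic carbon. The new hydroxy sits where compounds 1 and 3 carry their ether chains, but without any chain attached.

Going by the values given here, no step between two measured compounds isolates this change, so the expectation rests on the values alone. Because compound 2 gives 1070000 nM while compounds 1 and 3 give far lower numbers, a downward step is expected for compound 4, but a smaller one than either of those gaps. The estimated step from compound 2 to compound 4 is a 7.1-fold lower number from compound 2 to compound 4 (0.85 log units; beyond the scatter). Compound 4 is therefore expected to give about 150000 nM, with a plausible range from 30000 nM to 700000 nM.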

Compound 4, half-maximal inhibitory concentration: 490000 nM
For compound 4 the middle estimate is 3.3-fold (0.51 log units) below the measured one; low and high end bracket the measured number.
By their numbers in this assay, from the lowest: compounds 3 and 1 (each within the scatter of the next); then compound 4; then compound 2.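

In this assay, hydroxy in place of carboxy on this aromatic carbon gives only a 2.2-fold lower number from compound 2 to compound 4 (0.34 log units; beyond the scatter), a modest step that shows losing the second carboxy group does little on its own. Compound 4, with a bare hydroxy on the carbon where the ether chains are attached in the other compounds, stays at 490000 nM and so remains far from compound 3 at 2510 nM and compound 1 at 4790 nM, which places the low numbers in this small set with the compounds that carry a chain on that oxygen, rather than with the absence of carboxy. No measurement available here explains the size of this step or the low numbers of the two chain-bearing compounds.

What stays open is how much of a chain is needed on this oxygen: the compounds shown do not tell whether a short methoxy group or a plain benzyloxy group without halogens would already bring the number down. They also leave open how an amine on the same aromatic carbon would compare with the hydroxy of compound 4.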